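Swapping the Aromatic Group on a Shared Core

This account rests on a few compounds, and the source may have more. Where it says the series, first, only, none or still open, it means among the compounds named here.

In a functional assay on SK-OV-3 cells (Homo sapiens) for inhibition, read by CCK-8 assay, with a stated time of 70 h (a higher number here means a weaker inhibitor, a lower number a stronger inhibitor), compound 1 `Nc1ccccc1COc1ccc(OCCOCCNC2CCCC2)cc1` gives 14000 nM, compound 2 `Cc1ccc(COc2ccc(OCCOCCNC3CCCC3)cc2)cc1` gives 17200 nM, and compound 3 `O=[N+]([O-])c1ccc(COc2ccc(OCCOCCNC3CCCC3)cc2)cc1` gives 20300 nM. Compound 3 therefore stands within the usual scatter of both others. Compound 4 `COC(=O)c1cccc(COc2ccc(OCCOCCNC3CCCC3)cc2)c1` differs from it in one place: 3-(methoxycarbonyl)phenyl in place of 4-nitrophenyl on a saturated chain carbon bound to an oxygen on an aromatic ring. That is 3-(methoxycarbonyl)phenyl in place of 4-nitrophenyl on a saturated chain carbon bound to an oxygen on an aromatic ring. Within the data shown here, the steps that bear on this swap changed the same group: a 1.2-fold higher number from compound 1 to compound 2 (0.09 log units; within the scatter), a 1.5-fold higher number from compound 1 to compound 3 (0.16 log units; within the scatter) and a 1.2-fold higher number from compound 2 to compound 3 (0.07 log units; within the scatter). All three lie within the scatter, though none involved 3-(methoxycarbonyl)phenyl, so no step beyond the scatter is expected in this assay. The expected step is a 1.2-fold lower number from compound 3 to compound 4 (0.08 log units; within the scatter). The estimate for compound 4 is 17000 nM, with an expected range of 9000 nM to 32000 nM.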

Compound 4, half-maximal inhibitory concentration: 45500 nM
For compound 4 the middle estimate is 2.7-fold (0.43 log units) below the measured one, and the stated range ends below it.
By their numbers in this assay, from the lowest: compounds 1, 2 and 3 (each within the scatter of the next); then compound 4.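

In this assay this position, where earlier swaps stayed within the scatter, first shows a real difference: 3-(methoxycarbonyl)phenyl gives a 2.2-fold higher number from compound 3 to compound 4 (0.35 log units; beyond the scatter) and a 2.6-fold higher number from compound 2 to compound 4 (0.42 log units; beyond the scatter) and a 3.3-fold higher number from compound 1 to compound 4 (0.51 log units; beyond the scatter). The entering and leaving groups match in hydrogen-bond donors, acceptors and net charge, so these counts do not separate them. Nothing measured here explains the step. Going by these compounds, whether the weaker result belongs to the methoxycarbonyl group itself remains open. A carboxylic acid or an amide on the same ring would help test this.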